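Phenol ether variation on the thiazole-biaryl series

The source may report more compounds than this note shows. Statements on the series, on what has been measured and on what is new or still open speak of the compounds shown alone.

Measured so far:
- compound 1, `CCCCc1sc(-c2ccc(Oc3ccc(Cl)cc3)cc2)nc1-c1ccc(OCCCN(CC)CC)cc1`: 57%
- compound 2, `CCCCc1sc(-c2ccc(Oc3ccc(Cl)cc3)cc2)nc1-c1ccc(O)cc1`: 0.2%

In an assay on isolated protein for antagonist activity at advanced glycosylation end product-specific receptor (Homo sapiens), read by ELISA, with a stated time of 60 min, tested at 10 uM (on this read-out lower numbers stand for less inhibition and higher numbers for more inhibition at the one concentration tested (going by the name of the read-out)), compound 1 gives 57%, and compound 2 gives 0.2%, the lower of the two numbers shown. For the measured compounds named here, the only measured step, a number 56.8 percentage points lower from compound 1 to compound 2 (beyond the scatter), shows that replacing the 3-(diethylamino)propyl chain with hydrogen on the aromatic oxygen removes nearly all inhibition.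

Compound 3, `CCCCc1sc(-c2ccc(Oc3ccc(Cl)cc3)cc2)nc1-c1ccc(OCc2ccccc2)cc1`, carries benzyl in place of hydrogen on an oxygen on an aromatic ring. Going by the values given here, the change reverses the direction of the one known step by re-occupying that oxygen, but with a group lacking the amine of compound 1, so the step from compound 1 to compound 2 bears on it only in part. Some recovery of inhibition is expected, but less than the full swing seen in compound 1; the expected step is a number 19.8 percentage points higher from compound 2 to compound 3 (beyond the scatter). For compound 3 the estimate in this assay is 20%, within 0% to 55%.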

Compound 3, a percentage reported as inhibition, at one concentration (the size of the read-out at that concentration, not a potency): 2.4%
Compound 3: middle estimate off by 17.6 percentage points, on the high side; measured number inside the range.
By their numbers in this assay, from the lowest: compounds 2 and 3 (each within the scatter of the next); then compound 1.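

In this assay, placing benzyl on the oxygen on an aromatic ring does not set the ether apart from the free hydroxy: the hydroxy to benzyloxy change gives a number 2.2 percentage points higher from compound 2 to compound 3 (within the scatter). Occupying that oxygen is thus not enough in itself, and the change from the diethylamino-bearing chain to the benzyl ether gives a number 54.6 percentage points lower from compound 1 to compound 3 (beyond the scatter), leaving compound 1 as the only one of the three beyond the scatter of the others. No available evidence bears on why the numbers fall this way.

Open, as far as these compounds go, is whether the inhibition of compound 1 depends on the diethylamino group or on the chain that carries it. A morpholine or a carboxylic acid at the end of the same propyl chain, or a plain butyl chain on that oxygen, would address this.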